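A few compounds are considered here, and "the series" means these few. Any claim that something is new, unique, unknown or untested is made for them only; others in the source may bear on it.

Compound 1 `COC(=O)c1cccc(-c2cc(C(=O)Nc3ccncc3)ccc2CN)c1` gives 2.9 nM in an assay on isolated protein for inhibition of Rho-associated protein kinase 2 (Homo sapiens), read by radiometric assay; on this read-out lower numbers stand for stronger inhibition and higher numbers for weaker inhibition. Among the compounds with values here, compound 3 `CCCCCCOC(=O)c1cccc(-c2cc(C(=O)Nc3ccncc3)ccc2CN)c1` gives 22 nM in this assay; the step of a 7.6-fold higher number from compound 1 to compound 3 (0.88 log units; beyond the scatter) is the only measured change on the ester chain carbon and it weakens inhibition. Compound 2 `CCCOC(=O)c1cccc(-c2cc(C(=O)Nc3ccncc3F)ccc2CN)c1` gives 5.1 nM in this assay and stands second highest of the three numbers, with compound 1 within the scatter of it and compound 3 beyond it.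

Compound 4 `NCc1ccc(C(=O)Nc2ccncc2F)cc1-c1cccc(C(=O)OCC2CCCC2)c1` is not yet measured. It differs from compound 2 by cyclopentyl in place of ethyl on a saturated chain carbon bound to an oxygen next to a carbonyl group. Within the data shown here, the only measured step bearing on this place is a 7.6-fold higher number from compound 1 to compound 3 (0.88 log units; beyond the scatter), where a larger group on that carbon gave a weaker result beyond the scatter. The entering cyclopentyl is larger than the leaving ethyl, though the growth is smaller than the pentyl added in that step, so a weakening of intermediate size, likely beyond the scatter, is expected in this assay. On that basis compound 4 is expected to give 14 nM in this assay, with a range from 5 nM to 40 nM. The expected step is a 2.7-fold higher number from compound 2 to compound 4 (0.44 log units; beyond the scatter).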

Compound 4, half-maximal inhibitory concentration: 13 nM
Compound 4: the middle estimate sits 1.1-fold (0.03 log units) above what was measured; low and high end bracket the measured number.
By their numbers in this assay, from the lowest: compounds 1 and 2 (each within the scatter of the next); then compounds 4 and 3 (each within the scatter of the next).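

In this assay, cyclopentyl in place of ethyl on a saturated chain carbon bound to an oxygen next to a carbonyl group gives a 2.5-fold higher number from compound 2 to compound 4 (0.41 log units; beyond the scatter) and so extends the earlier picture from an open chain to a group carrying a ring. With a 7.6-fold higher number from compound 1 to compound 3 (0.88 log units; beyond the scatter) on a different parent, larger ester groups now raise the number beyond the scatter on two parents, and no step shown at this carbon goes against that. No measurement shown gives a reason for either rise.

Compound 4 gives 13 nM, and open is whether a hydroxyl or an amine at the end of the ester chain would lower or raise that number. Also open, on these data alone, is how a carboxylic acid in place of the ester, or phenyl in place of cyclopentyl, would read on the core of compound 2.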